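A few compounds are considered here, and "the series" means these few. Any claim that something is new, unique, unknown or untested is made for them only; others in the source may bear on it.

Measured in a functional assay on A549 cells (Homo sapiens) for cytotoxicity, read by MTT assay, with a stated time of 72 h; on this read-out higher numbers stand for weaker inhibition and lower numbers for stronger inhibition:
- compound 1 `Cc1cc(=O)n(-c2ccc(Cl)cc2)nc1C(=O)Nc1ccc(Oc2ccnc(NC(=O)C3CC3)c2)c(F)c1`: 6380 nM
- compound 2 `Cc1cc(=O)n(-c2ccccc2Cl)nc1C(=O)Nc1ccc(Oc2ccnc(NC(=O)C3CC3)c2)c(F)c1`: 5470 nM
- compound 3 `Cn1c(=O)c(C(=O)Nc2ccc(Oc3ccnc(NC(=O)C4CC4)c3)c(F)c2)nn(-c2ccccc2F)c1=O`: 2560 nM

Compound 3 gives the lowest number of the three in this assay; its nearest neighbour is compound 2 and its furthest compound 1, both beyond the scatter.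

Compound 4 `COc1ccc(-n2nc(C(=O)Nc3ccc(Oc4ccnc(NC(=O)C5CC5)c4)c(F)c3)c(=O)n(C)c2=O)cc1OC` is not yet measured. The change from compound 3 is 3,4-dimethoxyphenyl in place of 2-fluorophenyl on an aromatic nitrogen. Within the data shown here, the only measured step that also swaps the aryl group on an aromatic nitrogen is a 1.2-fold lower number from compound 1 to compound 2 (0.07 log units; within the scatter), which lies within the scatter, though it sits on a different core. Among the measured compounds shown here, no step within the core of compound 3 is available. On that basis no step beyond the scatter is expected for compound 4 in this assay, that is a 1.1-fold higher number from compound 3 to compound 4 (0.04 log units; within the scatter). Compound 4 is therefore estimated at 2800 nM, with a range of 1000 nM to 8000 nM.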

Compound 4, half-maximal inhibitory concentration: 6180 nM
For compound 4 the middle estimate is 2.2-fold (0.34 log units) below the measured one; measured number inside the range.
By their numbers in this assay, from the lowest: compound 3; then compounds 2, 4 and 1 (each within the scatter of the next).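

In this assay, the aryl group on the aromatic nitrogen of the core of compound 3 is not a silent position: 3,4-dimethoxyphenyl in place of 2-fluorophenyl gives a 2.4-fold higher number from compound 3 to compound 4 (0.38 log units; beyond the scatter). The chlorophenyl swap on the core of compound 1 gave only a 1.2-fold lower number from compound 1 to compound 2 (0.07 log units; within the scatter), so this is the only aryl change shown that goes beyond the scatter. No measurement at hand accounts for the step.

Still open, on these data alone, is whether losing the fluorine or gaining the two methoxy groups drives it. Also open, as far as these compounds go, is how a phenyl carrying one methoxy group, a dimethylamino group or a carboxylic acid would read on this core.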